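The source may hold more compounds than are shown below. What is called first, only, known or untested is meant among the compounds shown, and "the series" means these compounds.

Measured compounds:
- compound 1 `O=C(O)CCNC(=O)c1ccc(CC(c2ccc(Cl)cc2)c2nc(-c3ccc(C(F)(F)F)cc3)cs2)cc1` gives 381 nM in an in vitro assay on BHK cells for displacement of a labelled ligand from gastric inhibitory polypeptide receptor (Homo sapiens), read by scintillation proximity assay; on this read-out higher numbers stand for weaker inhibition and lower numbers for stronger inhibition
- compound 2 `O=C(O)CCNC(=O)c1ccc(CN(c2ccc(Cl)cc2)c2nc(-c3ccc(C(F)(F)F)cc3)cs2)cc1` gives 649 nM in this assay
- compound 3 `O=C(O)CCNC(=O)c1ccc(CN(c2ccc(C(F)(F)F)cc2)c2nc(-c3ccc(Cl)cc3)cs2)cc1` gives 990 nM in this assay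

Among these three numbers, compound 2 holds the second highest. Its nearest neighbour is compound 3 and its furthest is compound 1, yet both gaps lie within the usual scatter of repeated measurements, so the three compounds cannot be set apart from one another on these values. Compound 2 and compound 3 carry the same two substituents, chloro and trifluoromethyl, on exchanged aryl rings, and their numbers do not separate beyond the scatter.

Compound 4 `O=C(O)CCNC(=O)c1ccc(CN(c2ccc(SC(F)(F)F)cc2)c2nc(-c3ccc(C(F)(F)F)cc3)cs2)cc1` has not yet been measured. It differs from compound 2 in a single place: (trifluoromethyl)sulfanyl in place of chloro on an aromatic carbon. For the measured compounds named here, no pair of measured compounds differs in exactly this way, so the step has no direct precedent in the data. The step from compound 2 to compound 4 is expected to be small, a 1.2-fold lower number from compound 2 to compound 4 (0.07 log units; within the scatter), with no direction that would stand out beyond the scatter. On that basis compound 4 is estimated at 550 nM, with a range from 200 nM to 1500 nM.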

Compound 4, half-maximal inhibitory concentration: 777 nM
Estimate against measurement, compound 4: 1.4-fold (0.15 log units) below, and the stated range covers the measured number.
By their numbers in this assay, from the lowest: compounds 1, 2, 4 and 3 (each within the scatter of the next, the first and the last beyond it).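

In this assay the change from 4-chlorophenyl to 4-((trifluoromethyl)sulfanyl)phenyl gives a 1.2-fold higher number from compound 2 to compound 4 (0.08 log units; within the scatter) and stays within the scatter, so the two compounds cannot be told apart on this read-out. For the compounds shown here, this is the first step that alters a single group at this position, since compound 2 and compound 3 differ by an exchange of two groups and could not show what one substituent on this ring does alone. Here a single chlorine gives way to a group of five heavy atoms that adds one hydrogen-bond acceptor, and the reading does not separate from that of compound 2; nothing measured here bears on why this is so.

As far as these compounds go, whether a different group at this position, such as an amine, a methoxy group or a carboxylic acid, would move the number beyond the scatter remains open. So does whether (trifluoromethyl)sulfanyl would behave in the same way in place of the trifluoromethyl group on the other aryl ring of compound 2.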